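This account rests on a few compounds, and the source may have more. Where it says the series, first, only, none or still open, it means among the compounds named here.

Working notes on the series, which shares the core seen in compound 3 `O=S(=O)(NCCCNCc1cccc(Cl)c1)c1cc(C(F)(F)F)cc(C(F)(F)F)c1` and varies only the aryl group on a saturated chain carbon bound to an amine nitrogen. In a functional assay on PANC-1 cells (Homo sapiens) for inhibition, read by MTT assay, with a stated time of 72 h (on this read-out higher numbers stand for weaker inhibition of growth and lower numbers for stronger inhibition of growth), compound 3 gives 12000 nM, the highest number of the three measured. Compound 1 `O=S(=O)(NCCCNCc1ccc(Cl)c(C(F)(F)F)c1)c1cc(C(F)(F)F)cc(C(F)(F)F)c1` gives 10000 nM in this assay, and the step of a 1.2-fold higher number from compound 1 to compound 3 (0.08 log units; within the scatter) is within the scatter. Among the measured compounds shown here, compound 2 `O=S(=O)(NCCCNCc1cccc2ccccc12)c1cc(C(F)(F)F)cc(C(F)(F)F)c1` gives 2700 nM, with a 3.7-fold lower number from compound 1 to compound 2 (0.57 log units; beyond the scatter) and a 4.4-fold higher number from compound 2 to compound 3 (0.65 log units; beyond the scatter) as the only steps beyond the scatter.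

Compound 4 `O=S(=O)(NCCCNCc1ccc(Cl)cc1)c1cc(C(F)(F)F)cc(C(F)(F)F)c1` is not yet measured. The change from compound 3 is 4-chlorophenyl in place of 3-chlorophenyl on a saturated chain carbon bound to an amine nitrogen. For the measured compounds named here, no measured step moves a single chlorine around a phenyl ring, so the nearest guide is compound 1, which also carries a chlorine at the 4-position; in this assay compound 1 gives 10000 nM, which sits within the scatter of compound 3. The step of a 1.2-fold lower number from compound 3 to compound 4 (0.08 log units; within the scatter) is therefore expected to stay within the scatter. For compound 4 the expected value in this assay is 10000 nM, with a range from 4000 nM to 25000 nM.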

Compound 4, concentration for 50% growth inhibition: 4900 nM
The estimate for compound 4 lay 2.0-fold (0.31 log units) above the measured number, and the stated range covers the measured number.
By their numbers in this assay, from the lowest: compounds 2 and 4 (each within the scatter of the next); then compounds 1 and 3 (each within the scatter of the next).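

In this assay, among the compounds shown here, 4-chlorophenyl in place of 3-chlorophenyl gives a 2.4-fold lower number from compound 3 to compound 4 (0.39 log units; beyond the scatter), so on a saturated chain carbon bound to an amine nitrogen the place of the chlorine on the ring matters, which the earlier compounds could not show. Hydrogen in place of trifluoromethyl on an aromatic carbon gives a 2.0-fold lower number from compound 1 to compound 4 (0.31 log units; beyond the scatter), and 4-chlorophenyl in place of naphthalen-1-yl gives a 1.8-fold higher number from compound 2 to compound 4 (0.26 log units; within the scatter), so a single substituted phenyl ring now stands within the scatter of the naphthalen-1-yl group. Nothing at hand accounts for these steps.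

Still open, as far as these compounds go, is whether 2-chlorophenyl would sit with either chlorophenyl compound, and whether 4-bromophenyl or 4-methoxyphenyl would hold the number of compound 4 4900 nM. Also open, from the compounds shown here alone, is whether the difference between the two chlorophenyl groups survives on a longer chain.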